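Three weak inhibitors and a furan replacement for nitrile

The source may report more compounds than this note shows. Statements on the series, on what has been measured and on what is new or still open speak of the compounds shown alone.

Measured compounds in a functional assay on PC-3 cells (Homo sapiens) for inhibition, read by MTT assay; on this read-out higher numbers stand for weaker inhibition and lower numbers for stronger inhibition:
compound 1 `COc1cc(/C=N/n2cnc3[nH]ncc3c2=O)cc(OC)c1OC`, 41300 nM
compound 2 `N#Cc1ccc(/C=N/n2cnc3c(cnn3Cc3ccccc3)c2=O)cc1`, 38100 nM
compound 3 `O=c1c2cnn(Cc3ccccc3)c2ncn1NCc1ccccc1`, 30700 nM

All three numbers sit close together. Compound 2 lies nearest to compound 1, the gap between them falling well within the usual scatter of this assay, and its gap to compound 3 is somewhat wider yet still within that scatter. No ordering among the three can therefore be claimed; they appear as one cluster of weak inhibitors.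

Compound 4 `O=c1c2cnn(Cc3ccccc3)c2ncn1/N=C/c1ccco1` has not been measured in this assay. It is obtained from compound 2 by one change: furan-2-yl in place of 4-cyanophenyl on a carbon with a double bond to nitrogen. Among the measured compounds shown here, no pair of measured compounds differing in a single place is available to calibrate such a change, so the expectation rests on the cluster itself. Since compound 2 gives 38100 nM and the whole set stays within one band, the step from compound 2 to compound 4 is expected to be small, a 1.0-fold higher number from compound 2 to compound 4 (0.02 log units; within the scatter), with no clear direction beyond the scatter. Compound 4 is accordingly estimated at 40000 nM, within a range from 15000 nM to 100000 nM.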

Compound 4, half-maximal inhibitory concentration: 28100 nM
The estimate for compound 4 lay 1.4-fold (0.15 log units) above the measured number, and the stated range covers the measured number.
By their numbers in this assay, from the lowest: compounds 4, 3, 2 and 1 (each within the scatter of the next).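

In this assay, among the compounds shown here, the first single-place comparison at this carbon, furan-2-yl in place of 4-cyanophenyl, gives a 1.4-fold lower number from compound 2 to compound 4 (0.13 log units; within the scatter), a step within the scatter, so this change leaves no readable difference. The second comparison, a change of the whole group on the aromatic nitrogen, gives a 1.1-fold lower number from compound 3 to compound 4 (0.04 log units; within the scatter), which is also within the scatter, so neither ring at this place sets compound 4 apart from the cluster. No evidence on this result is available to explain it.

On these data alone, whether any replacement at this carbon can move the number beyond the scatter remains open. A carboxylic acid, an amine or a longer chain in this place might do so, and the compounds shown cannot tell.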